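The source may report more compounds than this note shows. Statements on the series, on what has been measured and on what is new or still open speak of the compounds shown alone.

Three related compounds have been tested in a functional assay on PC-3 cells (Homo sapiens) for cytotoxicity, read by MTT assay, with a stated time of 72 h; on this read-out lower numbers stand for stronger inhibition of growth and higher numbers for weaker inhibition of growth. Compound 1 `C[Se]/C(=N\C(=O)c1cc2ccccc2s1)NC(=O)c1cc2ccccc2s1` gives 37200 nM, and compound 2 `CS/C(=N\C(=O)c1csc([N+](=O)[O-])c1)NC(=O)c1csc([N+](=O)[O-])c1` gives 41500 nM. Compound 3 `CS/C(=N\C(=O)c1ccno1)NC(=O)c1ccno1` gives 99200 nM, the highest of the three numbers; its gaps to compound 2 and to compound 1 both lie beyond the usual scatter, so compound 3 is the weakest inhibitor of growth among them. Compound 4 `O=C(/N=C(/NC(=O)c1ccno1)[Se]Cc1ccccc1)c1ccno1` has not been measured. It differs from compound 3 in one place: a group of 8 heavy atoms (7 carbon, 1 selenium; one six-membered aromatic ring of carbon only) in place of a group of 2 heavy atoms (1 carbon, 1 sulfur; no ring), on a carbon with a double bond to nitrogen. Among the compounds with values here, no measured pair shows a change of this kind, so the direction can only be guessed from the spread across the three compounds. A modest move toward stronger growth inhibition is expected, a step of a 2.0-fold lower number from compound 3 to compound 4 (0.30 log units; within the scatter). Compound 4 is therefore estimated at 50000 nM, with a range from 15000 nM to 160000 nM.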

Compound 4, concentration for 50% growth inhibition: 53100 nM
Compound 4: the middle estimate sits 1.1-fold (0.03 log units) below what was measured; the measured number falls inside the stated range.
By their numbers in this assay, from the lowest: compounds 1, 2, 4 and 3 (each within the scatter of the next, the first and the last beyond it).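

On a carbon with a double bond to nitrogen, methylsulfanyl gives way to a much larger group holding selenium and a six-membered aromatic ring, and in this assay this swap gives a 1.9-fold lower number from compound 3 to compound 4 (0.27 log units; within the scatter). So this position accepts the larger group without a change beyond the scatter in this read-out. No measurement at hand offers an explanation for this step. Selenium and the ring entered together, so their separate shares remain unknown. On these data alone, how an amine or a longer chain on that carbon would behave also remains open.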